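A Cyclopropyl Group on the Sulfonyl Sulfur

The source may report more compounds than this note shows. Statements on the series, on what has been measured and on what is new or still open speak of the compounds shown alone.

Among the compounds with values here, compound 1 (`N[C@H]1C[C@@H](N2Cc3[nH]nc(NC(=O)C4CC4)c3C2)CO[C@@H]1c1cc(F)ccc1F`) gives 5.5 h in an ADME assay on the whole organism for metabolic stability, with Rattus norvegicus as the target (a higher number here means that the compound lasts longer, a lower number that the compound disappears faster), and compound 2 (`CS(=O)(=O)Nc1n[nH]c2c1CN([C@H]1CO[C@H](c3cc(F)ccc3F)[C@@H](N)C1)C2`) gives 2 h as the lower of the two numbers so far. Compound 3 (`N[C@H]1C[C@@H](N2Cc3[nH]nc(NS(=O)(=O)C4CC4)c3C2)CO[C@@H]1c1cc(F)ccc1F`) differs from compound 2 by cyclopropyl in place of methyl on a sulfonyl sulfur. Within the data shown here, the only measured step that bears on this is a 2.8-fold lower number from compound 1 to compound 2 (0.44 log units; beyond the scatter) (modest, but beyond the scatter). That step replaces cyclopropylcarbonyl with methylsulfonyl as a whole, and the data do not separate the share of the cyclopropyl from that of the carbonyl. Compound 3 should therefore recover only part of that step. A small rise is expected, a 1.5-fold higher number from compound 2 to compound 3 (0.18 log units; within the scatter) by this estimate, and it may not clear the scatter. Compound 3 is estimated at 3 h (expected range 1.5 h to 6 h).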

Compound 3, half-life: 1.5 h
Compound 3: middle estimate off by 2.0-fold (0.30 log units), on the high side, and the stated range covers the measured number.
By their numbers in this assay, from the lowest: compounds 3 and 2 (each within the scatter of the next); then compound 1.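

Cyclopropyl in place of methyl on a sulfonyl sulfur gives a 1.3-fold lower number from compound 2 to compound 3 (0.12 log units; within the scatter) in this assay, so at this position the two groups are not told apart by this read-out. With the cyclopropyl held constant, sulfonyl in place of carbonyl gives a 3.7-fold lower number from compound 1 to compound 3 (0.56 log units; beyond the scatter) in this assay, which places the gap on the exchange of carbonyl for sulfonyl in this pair, a separation that the step between the first two compounds could not make. Nothing measured here accounts for this result.

The compounds shown leave open how an acetyl group on that nitrogen would compare, which would show whether methyl and cyclopropyl also go unseparated on a carbonyl. They also leave open whether a dimethylamino group or a longer chain on the sulfonyl sulfur would stay within the scatter of these values.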